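The compounds below may be only part of what the source reports. "The series", "measured", "known", "first", "only" and "open" are said of these compounds alone.

Compound 2 `O=C(O)COc1ccc2c(=O)c(-c3ccc(O)cc3)coc2c1` is the starting point. In an assay (Cricetulus griseus) for inhibition of Monoamine oxidase (Homo sapiens) (on this read-out lower numbers stand for stronger inhibition and higher numbers for weaker inhibition), compound 2 gives only a limit, >> 9000 nM. Its neighbour, compound 1 `O=c1c(-c2ccc(O)cc2)coc2cc(OCCCCCCO)ccc12`, also gives only a limit in this assay, > 9000 nM. The step that the two limits leave unreadable from compound 1 to compound 2 therefore cannot be sized, as the limit of > 9000 nM in this assay, at which 1 of the 2 values shown sits, and the limit of >> 9000 nM in this assay, at which 1 of the 2 values shown sits, show. Compound 3 `CC(C)Oc1ccc2c(=O)c(-c3ccc(O)cc3)coc2c1` differs from compound 2 by isopropyl in place of carboxymethyl on an oxygen on an aromatic ring. With no readable step to lean on, compound 3 is expected to remain weak, with a step that the limit leaves unreadable from compound 2 to compound 3 that is more a guess than a trend. The estimate for compound 3 is 12000 nM, with a range from 3000 nM to 50000 nM.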

Compound 3, half-maximal inhibitory concentration: 200 nM
For compound 3 the middle estimate is 60-fold (1.78 log units) above the measured one, and the stated range ends above it.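

In this assay, isopropyl in place of carboxymethyl on the oxygen gives an at least 45-fold lower number from compound 2 to compound 3 (1.65 log units; beyond the scatter), and isopropyl in place of 6-hydroxyhexyl gives an at least 45-fold lower number from compound 1 to compound 3 (1.65 log units; beyond the scatter). Among these three compounds, the group on this oxygen therefore separates a readable inhibitor from two compounds that give only limits. Both steps are minimum sizes, not exact ones, and only isopropyl gives a readable value here.

As far as these compounds go, whether an amine or an unbranched butyl chain on this oxygen would keep this inhibition stays open. From the compounds shown here alone, the exact size of both steps also stays open.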